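Amine-to-ether linker change at the quinoxaline-type ring carbon

The compounds below may be only part of what the source reports. "The series", "measured", "known", "first", "only" and "open" are said of these compounds alone.

Compound 1 `COc1ccc(CNc2nc3cc(N)cc(N)c3nc2-c2ccccc2)cc1OC` gives 11500 nM in a functional assay on IGROV-1 cells (Homo sapiens) for inhibition, read by sulforhodamine B assay, with a stated time of 48 h; on this read-out higher numbers stand for weaker inhibition of growth and lower numbers for stronger inhibition of growth. Compound 2 `Nc1cc(N)c2nc(-c3ccccc3)c(NCc3ccc(F)cc3)nc2c1` gives 3090 nM in this assay. Among the compounds with values here, the only step measured so far, a 3.7-fold lower number from compound 1 to compound 2 (0.57 log units; beyond the scatter), exchanges the aryl group on the benzylic carbon and leaves the amino linker untouched. Compound 2 holds the lowest of the two numbers, with compound 1 the nearest and higher. Compound 3 `Nc1cc(N)c2nc(-c3ccccc3)c(Oc3ccc(F)cc3)nc2c1` differs from compound 2 in one place: 4-fluorophenoxy in place of (4-fluorobenzyl)amino on an aromatic carbon. Within the data shown here, no measured step alters the linker itself; the step from compound 1 to compound 2 bears only on the aryl group and gives no guide to swapping the amine for an ether. Among the measured compounds shown here, with no precedent, the expectation for compound 3 is a modest weakening of uncertain size, a 1.8-fold higher number from compound 2 to compound 3 (0.25 log units; within the scatter). Compound 3 is therefore estimated at 5500 nM in this assay, with a range of 1500 nM to 20000 nM.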

Compound 3, concentration for 50% growth inhibition: 28200 nM
Compound 3: the middle estimate sits 5.1-fold (0.71 log units) below what was measured; measured number outside the range, above it.
By their numbers in this assay, from the lowest: compound 2; then compound 1; then compound 3.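

In this assay, 4-fluorophenoxy in place of (4-fluorobenzyl)amino on this aromatic carbon gives a 9.1-fold higher number from compound 2 to compound 3 (0.96 log units; beyond the scatter), so the series responds at this position to the link to the aryl ring, and not only to the aryl group itself. The change is not a single-atom swap: the hydrogen-bond donors fall from 1 to 0, the heavy atoms from 9 to 8, and the saturated carbon of the chain is gone. No measurement on hand says why the number rises.

The compounds shown do not separate the change from nitrogen to oxygen from the loss of that carbon; 4-fluoroanilino, which keeps the nitrogen, and 4-fluorobenzyloxy, which keeps the carbon, would pull the two apart. Also open, from the compounds shown here alone, is whether 3,4-dimethoxyphenyl responds to the same linker change as the 4-fluorophenyl group does.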